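Adding a second carboxy group to compound 1

The source may report more compounds than this note shows. Statements on the series, on what has been measured and on what is new or still open speak of the compounds shown alone.

Measured compounds:
- compound 1, `CCCCCCCCCCOc1cc(OCCCCCCCCCC)cc(OCCCCCC(=O)N(c2ccc(C(=O)O)cc2)c2cccc(C(=O)O)c2)c1`: 58%
- compound 2, `CCCCCCCCCCOc1cc(OCCCCCCCCCC)cc(OCCCCCCN(Cc2ccc(C(=O)O)cc2)c2ccc(C(=O)O)cc2)c1`: "not determined" (no result reported)
- compound 3, `CCCCCCCCCCOc1cc(OCCCCCCCCCC)cc(OCCCCCCON=C(c2ccc(C(=O)O)cc2)c2ccc(C(=O)O)cc2)c1`: 2%

In an assay on isolated protein for binding affinity to P-selectin (Homo sapiens), read by ELISA, tested at 500 uM (on this read-out lower numbers stand for less inhibition and higher numbers for more inhibition at the one concentration tested (going by the name of the read-out)), compound 1 gives 58%, the higher of the two numbers that were obtained. Compound 3 gives 2% in this assay, a much lower reading, and the gap between compound 1 and compound 3 lies well beyond the usual scatter. Within the data shown here, for compound 2 the entry reads "not determined" (no result reported), so only two numbers are available to anchor any expectation.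

Compound 4, `CCCCCCCCCCOc1cc(OCCCCCCCCCC)cc(OCCCCCC(=O)N(c2cccc(C(=O)O)c2)c2ccc(C(=O)O)c(C(=O)O)c2)c1`, keeps the whole of compound 1 and differs from it in one place: carboxy in place of hydrogen on an aromatic carbon. The ring that carries the new group is the one already bearing a carboxy group, so the change reads as 4-carboxyphenyl becoming 3,4-dicarboxyphenyl.

Among the measured compounds shown here, no measured pair shows the effect of such a change, so the direction cannot be read from the data. The expected step from compound 1 to compound 4 in this assay is small, a number 3 percentage points lower from compound 1 to compound 4 (within the scatter), probably within the scatter. Compound 4 is therefore estimated at 55%, with a likely range from 25% to 80%.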

Compound 4, a percentage reported as inhibition, at one concentration (the size of the read-out at that concentration, not a potency): 102%
The estimate for compound 4 lay 47 percentage points below the measured number, outside the stated range (above it).
By their numbers in this assay, from the lowest: compound 3; then compound 1; then compound 4.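

In this assay, the change from 4-carboxyphenyl to 3,4-dicarboxyphenyl brings a large gain, a number 44 percentage points higher from compound 1 to compound 4 (beyond the scatter), so this aromatic carbon, ortho to a carboxy group, is not a silent position. Among these compounds, the earlier compounds could not show this: no two of them differed in one place, and this swap of hydrogen for carboxy gives the first direct reading of a single change on this ring. No measurement shown gives a reason for the gain.

The compounds shown do not tell whether the gain belongs to the carboxy group itself, or whether another group on the same carbon, such as an amine, a hydroxy group or a methyl ester, would give a similar reading. They also leave open whether a further carboxy group on the other aromatic ring would act alike.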